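This account rests on a few compounds, and the source may have more. Where it says the series, first, only, none or still open, it means among the compounds named here.

Compound 1 `COc1ncnc(Nc2ccc(C#N)c(OCC=C(C)C)c2)n1` gives 42000 nM in an ADME assay on MT2 cells (Homo sapiens) for cytotoxicity; a higher number here means that more compound is tolerated, a lower number that less compound is tolerated.
Compound 2 `COc1nc(Nc2ccc(C#N)c(OCC=C(C)C)c2)nc(OC)n1` reaches only a limit of the assay, > 100000 nM.
Compound 3 `COc1ccnc(Nc2ccc(Cl)c(OCC=C(C)C)c2)n1` gives 9000 nM in this assay.

On these data alone, the measured change methoxy in place of hydrogen on an aromatic carbon produced an at least 2.3-fold higher number from compound 1 to compound 2 (0.37 log units; beyond the scatter); the top of that step stays open because of the limit of > 100000 nM in this assay, at which 1 of the 3 values shown sits. The difference between the core of compound 1 and the core of compound 3 is not broken down here; of the two numbers, compound 3 gives the lower one. Compound 4 `COc1cc(OC)nc(Nc2ccc(Cl)c(OCC=C(C)C)c2)n1` is not yet measured and carries the same kind of change, (methoxy in place of hydrogen on an aromatic carbon), yet the surroundings differ: here the site is on a six-membered aromatic ring with 2 nitrogen, next to the ring nitrogen, whereas before it was on a ring with 3 nitrogen, between two ring nitrogen atoms. Resting on the earlier step of an at least 2.3-fold higher number from compound 1 to compound 2 (0.37 log units; beyond the scatter), the expected movement for compound 4 is a 3.3-fold higher number from compound 3 to compound 4 (0.52 log units; beyond the scatter). Compound 4 is estimated at 30000 nM.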

Compound 4, half-maximal cytotoxic concentration: 28000 nM
The estimate for compound 4 lay 1.1-fold (0.03 log units) above the measured number; low and high end bracket the measured number.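

In this assay, methoxy in place of hydrogen on an aromatic carbon gives a 3.1-fold higher number from compound 3 to compound 4 (0.49 log units; beyond the scatter), so the change moves the number in the same direction on a second core. Whether the size of the step carries over cannot be settled: the same change on two cores in this assay, an at least 2.3-fold higher number (0.37 log units; beyond the scatter) from compound 1 to compound 2 and a 3.1-fold higher number (0.49 log units; beyond the scatter) from compound 3 to compound 4; the limit leaves it open whether they differ. Two pairs give the direction on these two cores only and set no general rule, and the earlier step has an open top: the limit of > 100000 nM in this assay, at which 1 of the 4 values shown sits.

The compounds shown leave open how an amine or an ethoxy group at the same aromatic carbon would move the number. On these data alone, it is also open whether the methoxy step would hold with a longer chain in place of the ether chain on the shared aniline part.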